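Thiophene in place of pyridine on a weakly cytotoxic core

A few compounds are considered here, and "the series" means these few. Any claim that something is new, unique, unknown or untested is made for them only; others in the source may bear on it.

Measured compounds:
compound 1 `Oc1cccc(-c2cc(-c3cccnc3)nc(-c3ccccc3Cl)c2)c1` — "not determined" (no result reported)
compound 2 `Oc1cccc(-c2cc(-c3ccc(Cl)cc3)nc(-c3cccnc3)c2)c1` — 26800 nM

Compound 1 `Oc1cccc(-c2cc(-c3cccnc3)nc(-c3ccccc3Cl)c2)c1` stands without a number: in a functional assay on DU-145 cells (Homo sapiens) for cytotoxicity, read by CCK-8 assay and cell counting, with a stated time of 2 days (a higher number here means a weaker inhibitor, a lower number a stronger inhibitor), compound 1 gives "not determined" (no result reported). Its only measured relative, compound 2 `Oc1cccc(-c2cc(-c3ccc(Cl)cc3)nc(-c3cccnc3)c2)c1`, is an isomer that carries the same three aryl groups on the shared core in a different arrangement, with the chlorine moved on the chlorophenyl ring, and in this assay compound 2 gives 26800 nM, a weak result. Compound 3 `Oc1cccc(-c2cc(-c3ccsc3)nc(-c3ccccc3Cl)c2)c1` is the step from compound 1 that this account follows: thiophen-3-yl in place of pyridin-3-yl on an aromatic carbon. Nothing measured here connects the two heteroaryl groups, so no direction is expected with confidence; the change is expected to stay within the usual scatter rather than move the number far, and compound 3 is expected to remain weak like compound 2. Compound 3 is estimated at 20000 nM, in a range of 5000 nM to 80000 nM.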

Compound 3, half-maximal inhibitory concentration: 1970 nM
Beside the measured number, compound 3's estimate is 10-fold (1.01 log units) above it, outside the stated range (below it).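

In this assay, going by these compounds alone, compound 1 gives "not determined" (no result reported), so no step from compound 1 to compound 3 can be read. The compounds shown leave open what thiophen-3-yl in place of pyridin-3-yl does to the number. Nothing shown bears on the result for compound 3.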